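Trimming the Acyl Group on a Fused Amide Core

The compounds below may be only part of what the source reports. "The series", "measured", "known", "first", "only" and "open" are said of these compounds alone.

Compound 1, `CCCC(=O)N1c2ccccc2CCC1C(=O)Nc1cc(C(F)(F)F)cc(C(F)(F)F)c1`, gives 18600 nM in a functional assay on PC-3 cells (Homo sapiens) for cytotoxicity, read by sulforhodamine B assay, with a stated time of 72 h; on this read-out higher numbers stand for weaker inhibition of growth and lower numbers for stronger inhibition of growth.
Compound 2, `CCC(=O)N1c2ccccc2CCC1C(=O)Nc1cc(C(F)(F)F)cc(C(F)(F)F)c1`, gives 8540 nM in this assay.

Among the measured compounds shown here, compound 2 holds the lowest of the two numbers, set apart from its single neighbour: a 2.2-fold lower number from compound 1 to compound 2 (0.34 log units; beyond the scatter). Compound 3, `O=C(Nc1cc(C(F)(F)F)cc(C(F)(F)F)c1)C1CCc2ccccc2N1`, takes this one step further: hydrogen in place of propanoyl on a nitrogen on an aromatic ring in a ring. For the measured compounds named here, only the step from compound 1 to compound 2 bears on it; that step was modest yet beyond the scatter, with the shorter chain giving the lower number. Removing the chain altogether is a larger change than any measured, so the expectation is uncertain. A further modest lowering, a 1.6-fold lower number from compound 2 to compound 3 (0.19 log units; within the scatter), is estimated for compound 3, expected at 5500 nM with a range from 1800 nM to 20000 nM.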

Compound 3, concentration for 50% growth inhibition: 8120 nM
Compound 3: the middle estimate sits 1.5-fold (0.17 log units) below what was measured; low and high end bracket the measured number.
By their numbers in this assay, from the lowest: compounds 3 and 2 (each within the scatter of the next); then compound 1.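

At this nitrogen, the propanoyl group can be replaced by hydrogen with no real shift in this assay: the result is a 1.1-fold lower number from compound 2 to compound 3 (0.02 log units; within the scatter). Only butanoyl-bearing compound 1 stands apart, as the full removal gives a 2.3-fold lower number from compound 1 to compound 3 (0.36 log units; beyond the scatter), so among these three compounds a shorter chain or none at all reads the same. Nothing available explains this flat result.

Still open, as far as these compounds go, is whether a longer chain, a benzoyl group or a simple methyl on this nitrogen would move the number. An amine or a carboxylic acid carried on the acyl chain is equally untested by the compounds shown here.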